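The source may report more compounds than this note shows. Statements on the series, on what has been measured and on what is new or still open speak of the compounds shown alone.

Measured so far in an assay for inhibition of beta-galactosidase (Bos taurus), read by spectrophotometry, with a stated time of 30 min; a higher number here means a weaker inhibitor, a lower number a stronger inhibitor:
Compound 1 `CCCCNC(=O)N1C[C@H](O)[C@@H](O)[C@H](O)[C@H]1CO` gives 27000 nM.
Compound 2 `N=C(NCCOCCO)N1C[C@H](O)[C@@H](O)[C@H](O)[C@H]1CO` gives only a limit, > 1000000 nM.
Compound 3 `N=C(NCc1ccccc1)N1C[C@H](O)[C@@H](O)[C@H](O)[C@H]1CO` gives 5100 nM.

Compound 2 therefore stands at the edge of what this assay can report: it sits at the limit of > 1000000 nM in this assay, at which 1 of the 3 values shown sits, and no number is known for it. Compound 4 `N=C(NCCCc1ccccc1)N1C[C@H](O)[C@@H](O)[C@H](O)[C@H]1CO` differs from compound 2 by benzyl in place of 2-hydroxyethoxy on a saturated chain carbon, two bonds along the chain from an amine nitrogen. Among the measured compounds shown here, only one measured step bears on this change, namely an at least 190-fold lower number from compound 2 to compound 3 (2.29 log units; beyond the scatter), in which a phenyl ring entered in place of the hydroxyethoxy-bearing group and the limit turned into a measurable number. Compound 4 carries the same aromatic ring, placed two bonds along the chain from the amine nitrogen rather than directly on it. A step of the same direction and of similar size is expected, from the limit down into the measurable range. The step from compound 2 to compound 4 is expected to be an at least 120-fold lower number from compound 2 to compound 4 (2.09 log units; beyond the scatter). Compound 4 is expected to give 8000 nM, with a range of 2000 nM to 40000 nM.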

Compound 4, half-maximal inhibitory concentration: 6200 nM
Compound 4: middle estimate off by 1.3-fold (0.11 log units), on the high side, within the range that was stated.
By their numbers in this assay, from the lowest: compounds 3 and 4 (each within the scatter of the next); then compound 1. At a limit, above all of these: compound 2.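

In this assay, benzyl in place of 2-hydroxyethoxy gives an at least 160-fold lower number from compound 2 to compound 4 (2.20 log units; beyond the scatter), so a second compound with an aromatic ring moves into the measurable range. The ring can also stand two bonds along the chain from an amine nitrogen with no change beyond the scatter: compound 3 gives 5100 nM and compound 4 gives 6200 nM, and these two values lie within the usual scatter of each other. The full size of the step remains unknown, since compound 2 has only a limit: the limit of > 1000000 nM in this assay, at which 1 of the 4 values shown sits.

From the compounds shown here alone, it remains open whether a longer chain ending in the same phenyl ring would stay in this range. Also open, going by these compounds, is what a cyclohexyl group or a carboxylic acid would give at the end of the chain, so the role of the aromatic ring itself remains unsettled.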